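A few compounds are considered here, and "the series" means these few. Any claim that something is new, unique, unknown or untested is made for them only; others in the source may bear on it.

- compound 1 `CCOC(=O)c1cc([Se]c2ccccc2)c2cc(Br)ccc2n1`: 12400 nM
- compound 2 `CCOC(=O)c1cc([Se]c2ccccc2)c2cc(OC)ccc2n1`: 33000 nM

In a functional assay on SK-MEL-147 cells (Homo sapiens) for cytotoxicity, read by MTT assay, with a stated time of 24 h (on this read-out higher numbers stand for an effect only at larger amounts of compound and lower numbers for an effect already at smaller amounts), compound 2 holds the higher of the two numbers at 33000 nM, so it needs the larger amount to show an effect. The move to compound 3 `COc1ccc2nc(-c3cccs3)cc([Se]c3ccccc3)c2c1` keeps the methoxy group and changes one place, next to the ring nitrogen: thiophen-2-yl in place of ethoxycarbonyl (thiophen-2-yl in place of ethoxycarbonyl on an aromatic carbon).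

Going by the values given here, only one measured step exists, a 2.7-fold higher number from compound 1 to compound 2 (0.43 log units; beyond the scatter). It was modest and concerned a different place on the core, so it offers only a rough guide to size. Among the compounds with values here, no measured step touches the ethoxycarbonyl, and the data give no firm direction. A change of similar or smaller size is therefore a fair expectation. The expected step in this assay is a 1.7-fold lower number from compound 2 to compound 3 (0.22 log units; within the scatter), a tentative estimate with its direction left open. Compound 3 is estimated at 20000 nM, with an expected range of 6000 nM to 65000 nM.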

Compound 3, half-maximal effective concentration: > 150000 nM
Compound 3: a limit, no number (the forecaster's own chance of this, stated with the estimate: 10%); middle value at least 7.5-fold (0.87 log units) from the limit.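

Swapping ethoxycarbonyl for thiophen-2-yl next to the ring nitrogen in this assay gives an at least 4.5-fold higher number from compound 2 to compound 3 (0.65 log units; beyond the scatter), so this place on the shared core clearly affects the read-out, which the earlier pair could not show. That is a larger step than a 2.7-fold higher number from compound 1 to compound 2 (0.43 log units; beyond the scatter), which came from a change at another place on the core. The value of compound 3 is a limit and not a number: the limit of > 150000 nM in this assay, at which 1 of the 3 values shown sits.

A single swap cannot separate what is lost with the ethoxycarbonyl from what arrives with the thiophen-2-yl, and the reason for the weaker effect stays unknown. A carboxylic acid, an amide or a phenyl group at this place would help to tell these apart, as would thiophen-2-yl paired with bromo instead of methoxy.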